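The source may hold more compounds than are shown below. What is called first, only, known or untested is meant among the compounds shown, and "the series" means these compounds.

Measured in a functional assay on HeLa cells (Homo sapiens) for inhibition, read by CCK-8 assay, with a stated time of 48 h; on this read-out higher numbers stand for weaker inhibition and lower numbers for stronger inhibition:
Compound 1 `COc1cc(-c2ccnc3cc(-c4c[nH]c5ccccc45)nn23)cc(OC)c1OC`: 195 nM
Compound 2 `COc1cc(-c2ccnc3cc(-c4cccc(C#N)c4)nn23)cc(OC)c1OC`: > 10000 nM
Compound 3 `COc1cc(-c2ccnc3cc(-c4ccc(C(C)=O)cc4)nn23)cc(OC)c1OC`: 1810 nM

Compound 2 gives > 10000 nM, which is a limit of the assay and not a number. Of the two true numbers, compound 3 holds the higher at 1810 nM, and the step to it is a 9.3-fold higher number from compound 1 to compound 3 (0.97 log units; beyond the scatter), a modest one. Compound 4 `COc1ccc(-c2cc3nccc(-c4cc(OC)c(OC)c(OC)c4)n3n2)cc1` has methoxy in place of acetyl on an aromatic carbon, para to a large group: methoxy in place of acetyl on an aromatic carbon. For the measured compounds named here, no measured step makes this exchange. The nearest is an at least 5.5-fold lower number from compound 2 to compound 3 (0.74 log units; beyond the scatter), at least modest, which swaps 3-cyanophenyl for 4-acetylphenyl. The large step of an at least 51-fold higher number from compound 1 to compound 2 (1.70 log units; beyond the scatter) and the step to compound 3 both replace 1H-indol-3-yl, which compound 4 also lacks. In this assay, the expected step is a 1.8-fold lower number from compound 3 to compound 4 (0.26 log units; within the scatter), a small move toward a lower number. For compound 4 the estimate is 1000 nM, with an expected range of 250 nM to 6000 nM.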

Compound 4, half-maximal inhibitory concentration: 373 nM
Estimate against measurement, compound 4: 2.7-fold (0.43 log units) above; low and high end bracket the measured number.
By their numbers in this assay, from the lowest: compounds 1 and 4 (each within the scatter of the next); then compound 3. At a limit, above all of these: compound 2.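

Methoxy in place of acetyl, para to a large group, gives a 4.9-fold lower number from compound 3 to compound 4 (0.69 log units; beyond the scatter), so this single exchange on the phenyl ring is enough to move the number beyond the scatter. With 4-methoxyphenyl in place of 1H-indol-3-yl the step is a 1.9-fold higher number from compound 1 to compound 4 (0.28 log units; within the scatter), so among these compounds the indole is not needed for a number of this order. The step of an at least 26-fold lower number from compound 2 to compound 4 (1.42 log units; beyond the scatter) is only a bound, as it starts from a limit and not a number: the limit of > 10000 nM in this assay, at which 1 of the 4 values shown sits.

The compounds shown leave open whether an amine, a hydroxyl or a longer chain such as ethoxy at this place would do as well as methoxy.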